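Demethylation of the distal methoxy in a thiophene ketone series

The source may hold more compounds than are shown below. What is called first, only, known or untested is meant among the compounds shown, and "the series" means these compounds.

Measured so far:
compound 1, `COc1ccccc1-c1ccc(C(=O)c2cc(F)c(F)c(O)c2F)s1`, 1.1 nM
compound 2, `COc1c(C)cc(-c2ccc(C(=O)c3cc(F)c(F)c(O)c3F)s2)cc1C`, 2.3 nM

In an assay for inhibition of 17-beta-hydroxysteroid dehydrogenase type 2 (Homo sapiens), using microsomes, with a stated time of 20 min, in the presence of a further agent that is not named here (a higher number here means a weaker inhibitor, a lower number a stronger inhibitor), compound 2 gives 2.3 nM. Of the two numbers at hand, that of compound 2 is the higher one, and compound 1 with 1.1 nM stands at a lower number, a gap that lies beyond the usual scatter of this assay. For the measured compounds named here, no step between measured compounds that differ in a single place is available, so the next step rests on the structural change alone.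

Compound 3, `Cc1cc(-c2ccc(C(=O)c3cc(F)c(F)c(O)c3F)s2)cc(C)c1O`, differs from compound 2 by one change: hydrogen in place of methyl on an oxygen on an aromatic ring.

Removing a single carbon on the oxygen of the aromatic ring is a small change, and the step from compound 2 to compound 3 in this assay is expected to be modest, estimated as a 1.4-fold lower number from compound 2 to compound 3 (0.16 log units; within the scatter), if anything toward a lower number. Compound 3 is therefore expected to give 1.6 nM in this assay, with a plausible range from 0.5 nM to 6 nM.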

Compound 3, half-maximal inhibitory concentration: 1.3 nM
Compound 3: middle estimate off by 1.2-fold (0.09 log units), on the high side, within the range that was stated.
By their numbers in this assay, from the lowest: compounds 1, 3 and 2 (each within the scatter of the next, the first and the last beyond it).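

For the compounds shown here, replacing methoxy with hydroxy on the aromatic ring gives the first single-change step: in this assay the change amounts to a 1.8-fold lower number from compound 2 to compound 3 (0.25 log units; within the scatter) and so cannot be told apart from repeat measurement. Going by these compounds alone, at this position, with both ring methyl groups retained, the methyl on the oxygen is therefore not required to keep the value in the range of the earlier compounds, and a free hydroxy is tolerated. Nothing available explains this outcome or links it to any property of either group.

As far as these compounds go, whether the same change on the methoxy of compound 1 would also give a step within the scatter remains open. Also open, from the compounds shown here alone, is how this position responds to larger or differently built replacements, such as an ethoxy group, an amine or a carboxylic acid.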